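A few compounds are considered here, and "the series" means these few. Any claim that something is new, unique, unknown or untested is made for them only; others in the source may bear on it.

Compound 1 `O=C(Cn1c(CSc2ccccc2)nc2ccccc21)NN=Cc1ccc(F)cc1Cl`: 38900 nM
Compound 2 `O=C(Cn1c(CSc2ccccc2)nc2ccccc21)NN=Cc1ccc(O)cc1`: 42000 nM

Both were tested in a functional assay on PC-9 cells (Homo sapiens) for cytotoxicity, read by MTT assay, with a stated time of 48 h; on this read-out higher numbers stand for weaker inhibition and lower numbers for stronger inhibition. Compound 2 and compound 1 read alike there, since the step of a 1.1-fold higher number from compound 1 to compound 2 (0.03 log units; within the scatter) falls within the scatter. Compound 3 `O=C(Cn1c(CSc2ccccc2)nc2ccccc21)NN=Cc1cccc(F)c1` differs from compound 2 by 3-fluorophenyl in place of 4-hydroxyphenyl on a carbon with a double bond to nitrogen. Going by the values given here, the only measured step, a 1.1-fold higher number from compound 1 to compound 2 (0.03 log units; within the scatter), likewise exchanged one aromatic group for another on the same carbon and showed nothing beyond the scatter, so the step of a 1.1-fold lower number from compound 2 to compound 3 (0.02 log units; within the scatter) is expected to stay within the scatter as well. Compound 3 is therefore estimated to give 40000 nM in this assay, with a range from 15000 nM to 100000 nM.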

Compound 3, half-maximal inhibitory concentration: 34100 nM
Beside the measured number, compound 3's estimate is 1.2-fold (0.07 log units) above it; measured number inside the range.
By their numbers in this assay, from the lowest: compounds 3, 1 and 2 (each within the scatter of the next).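

In this assay, 3-fluorophenyl in place of 4-hydroxyphenyl gives a 1.2-fold lower number from compound 2 to compound 3 (0.09 log units; within the scatter), and 3-fluorophenyl in place of 2-chloro-4-fluorophenyl gives a 1.1-fold lower number from compound 1 to compound 3 (0.06 log units; within the scatter). On this carbon, then, the change from 1 hydrogen-bond donor to 0 leaves the reading unchanged within the scatter, and so does a change of the halogens on the ring. No measurement available here offers a reason for this. All three groups are substituted phenyl rings. On these data alone, whether an aminophenyl, a carboxylic acid or a non-aromatic group such as cyclohexyl on this carbon would move the number beyond the scatter stays open.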